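A Phenoxypropyl Chain Replaces Naphthalen-2-yl on the Carbonyl

A few compounds are considered here, and "the series" means these few. Any claim that something is new, unique, unknown or untested is made for them only; others in the source may bear on it.

Of the compounds shown here, two built on a shared core have numbers so far. In a functional assay on HuT78 cells (Homo sapiens) for inhibition, read by sulforhodamine B assay, with a stated time of 72 h (a lower number here means a stronger inhibitor of growth, a higher number a weaker inhibitor of growth), compound 1 (`O=C(NO)c1cnc(N2C[C@@H]3CN(S(=O)(=O)c4ccc(OC(F)(F)F)cc4)C[C@@H]3C2)nc1`) gives 500 nM as its result. Compound 2 (`O=C(NO)c1cnc(N2C[C@H]3CN(C(=O)c4ccc5ccccc5c4)C[C@H]3C2)nc1`) gives 200 nM in the same test, the lower number of the pair, and the gap between them lies beyond the usual scatter. The two differ in more than one place, however, so that gap cannot be tied to any single group.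

Compound 3 (`O=C(NO)c1cnc(N2C[C@H]3CN(C(=O)CCCOc4ccccc4)C[C@H]3C2)nc1`) departs from compound 2 in one place only, with 3-phenoxypropyl in place of naphthalen-2-yl on a carbonyl carbon. The amide-type nitrogen in a ring stays bonded to that carbonyl. For the measured compounds named here, no measured pair yet shows what such an exchange does, so the expectation is a cautious one, anchored on compound 2 at 200 nM as the closest reference. No step beyond the scatter is expected in this assay and a 1.5-fold higher number from compound 2 to compound 3 (0.18 log units; within the scatter) is the estimated size. For compound 3 the estimate is 300 nM with an expected range from 100 nM to 900 nM in this measurement.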

Compound 3, concentration for 50% growth inhibition: 800 nM
Compound 3: the middle estimate sits 2.7-fold (0.43 log units) below what was measured; low and high end bracket the measured number.
By their numbers in this assay, from the lowest: compound 2; then compounds 1 and 3 (each within the scatter of the next).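

In this assay, the exchange on the carbonyl carbon gives a 4.0-fold higher number from compound 2 to compound 3 (0.60 log units; beyond the scatter), a step beyond the scatter and the first in this set that can be tied to one place. It shows that this position does not treat all groups of 10 heavy atoms alike, since naphthalen-2-yl and 3-phenoxypropyl match in that count yet give clearly different numbers. The exchange alters several things at once, with 2 six-membered aromatic rings of carbon only giving way to one such ring on a chain that brings 1 hydrogen-bond acceptor, and no measurement shown here explains the step.

The compounds shown leave open whether the higher number goes with the loss of the second aromatic ring, with the chain, or with its oxygen, a question that a 3-phenylpropyl group or a plain phenyl on the same carbonyl would help to separate. Also open, as far as these compounds go, is whether this position tolerates an amine or a carboxylic acid at the end of a longer chain, and compound 1 cannot settle the matter, as it differs from compound 2 and compound 3 in more than one place.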